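Sulfone analogue expected to stay beyond the assay limit

The source may hold more compounds than are shown below. What is called first, only, known or untested is meant among the compounds shown, and "the series" means these compounds.

Compound 2 `CC(O)(CS(=O)(=O)c1ccc(Cl)cc1)c1nc(-c2ccc(Cl)cc2)no1` carries a sulfone and a 4-chlorophenyl group on the shared core. In a functional assay on DU-145 cells (Homo sapiens) for cytotoxicity, read by MTT assay (on this read-out lower numbers stand for stronger inhibition and higher numbers for weaker inhibition), compound 2 gives > 100000 nM, which is a limit of the assay and not a number. Compound 3 `CC(O)(CS(=O)(=O)c1ccccc1)c1nc(-c2ccc(Cl)cc2)no1`, with hydrogen in place of chloro on an aromatic carbon, also reaches only a limit in this assay, namely > 100000 nM. The step that the two limits leave unreadable from compound 2 to compound 3 therefore cannot be sized. Compound 1 `CC(O)(CSc1ccccc1)c1nc(-c2ccc(F)c(Cl)c2)no1` is a thioether rather than a sulfone and differs from compound 2 in two places; in this assay compound 1 gives 5500 nM.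

Compound 4 `CC(O)(CS(=O)(=O)c1ccc(Cl)cc1)c1nc(-c2ccc(F)c(Cl)c2)no1` has not been measured. It differs from compound 2 by 3-chloro-4-fluorophenyl in place of 4-chlorophenyl on an aromatic carbon. For the measured compounds named here, no measured pair differs in exactly this way, so no measured step bears directly on it; compound 1 merely shows that the entering group sits on a measured compound. Because the limit of > 100000 nM in this assay, at which 2 of the 3 values shown sit, covers both sulfones, the same outcome is expected for the new sulfone. Compound 4 is estimated to give about 100000 nM, with a range from 20000 nM to 300000 nM. The expected step of a number no higher from compound 2 to compound 4 (the limit leaves the size open) is accordingly none beyond the scatter, though from a limit it cannot be read.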

Compound 4, half-maximal inhibitory concentration: 35500 nM
Compound 4: middle estimate off by 2.8-fold (0.45 log units), on the high side, within the range that was stated.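

For the compounds shown here, this is the first change on the aryl group at this position, an aromatic carbon of the five-membered aromatic ring with 2 nitrogen and 1 oxygen, whose effect can be read at all, since the step between the two earlier sulfones cannot be read. In this assay, putting 3-chloro-4-fluorophenyl in place of 4-chlorophenyl gives an at least 2.8-fold lower number from compound 2 to compound 4 (0.44 log units; beyond the scatter), which shows that a sulfone on the shared core can give a measurable number and that the aryl group at this position affects the result. Compound 2 has only a limit and not a number, so the real step could be larger than the one printed here: the limit of > 100000 nM in this assay, at which 2 of the 4 values shown sit.

The compounds shown do not reveal how much of the step belongs to the fluorine and how much to the chlorine of the entering group, as no compound carries either change alone. They also leave open what would happen with an amine or a carboxylic acid on this aryl ring, and whether the sulfone alone, with nothing else changed, differs from the thioether.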